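A few compounds are considered here, and "the series" means these few. Any claim that something is new, unique, unknown or untested is made for them only; others in the source may bear on it.

Measured in a functional assay on cells (Cancer cell lines, Homo sapiens) for cytotoxicity, read by sulforhodamine B assay, with a stated time of 48 h; a higher number here means a weaker inhibitor of growth, a lower number a stronger inhibitor of growth:
compound 1 `O=C1N=C(N2N=C(c3ccccc3)CC2c2ccccc2O)S/C1=C1/C(=O)Nc2ccc(Br)cc21` — 240 nM
compound 2 `COc1ccc(C2CC(c3ccccc3)=NN2C2=NC(=O)/C(=C3\C(=O)Nc4ccc(Br)cc43)S2)cc1` — 180 nM
compound 3 `COc1ccc(C2CC(c3ccc4ccccc4c3)=NN2C2=NC(=O)/C(=C3\C(=O)Nc4ccc(Br)cc43)S2)cc1` — 46 nM

Compound 2 holds the second highest of the three numbers in this assay; its nearest neighbour is compound 1, with a 1.3-fold lower number from compound 1 to compound 2 (0.12 log units; within the scatter), and its furthest is compound 3, with a 3.9-fold lower number from compound 2 to compound 3 (0.59 log units; beyond the scatter). Compound 4 `CN(C)c1ccc(C2CC(c3ccccc3)=NN2C2=NC(=O)/C(=C3\C(=O)Nc4ccc(Br)cc43)S2)cc1` differs from compound 2 by dimethylamino in place of methoxy on an aromatic carbon. Within the data shown here, no measured step swaps this particular substituent: the step from compound 1 to compound 2 alters the same ring but exchanges a different group, and the step from compound 2 to compound 3 touches another ring. Among the measured compounds shown here, the one change recorded at this ring stayed within the scatter, so for compound 4 a step of no change at the digits printed from compound 2 to compound 4 (within the scatter) in this assay is expected, not beyond the scatter. Compound 4 is estimated at 180 nM, range 80 nM to 400 nM.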

Compound 4, concentration for 50% growth inhibition: 210 nM
For compound 4 the middle estimate is 1.2-fold (0.07 log units) below the measured one; low and high end bracket the measured number.
By their numbers in this assay, from the lowest: compound 3; then compounds 2, 4 and 1 (each within the scatter of the next).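

In this assay, among these compounds, dimethylamino in place of methoxy on the aromatic carbon para to a large group gives a 1.2-fold higher number from compound 2 to compound 4 (0.07 log units; within the scatter); this is the first reading of this exchange at that place. Against the 2-hydroxyphenyl group the reading is a 1.1-fold lower number from compound 1 to compound 4 (0.06 log units; within the scatter), so compounds 1, 2 and 4 all lie within the scatter of one another, with three different aryl groups on the saturated ring carbon. No supporting data bear on why this exchange reads as it does.

Still open, as far as these compounds go, is whether a carboxylic acid or a longer chain at this aromatic carbon would move the number. Also open, from the compounds shown here alone, is whether dimethylamino would read the same with naphthalen-2-yl in place of phenyl.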